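The source may hold more compounds than are shown below. What is called first, only, known or untested is meant among the compounds shown, and "the series" means these compounds.

Measured so far in an ADME assay on MT4 cells (Homo sapiens) for cytotoxicity, read by MTT assay; on this read-out higher numbers stand for lower toxicity in this test and lower numbers for higher toxicity in this test:
- compound 1, `Cc1cnc(Nc2ccc(C#N)cc2)nc1NC1CC1`: 360 nM
- compound 2, `N#Cc1ccc(Nc2nccc(NC3CC3)n2)cc1`: 1190 nM
- compound 3, `Cc1cc(NC2CC2)nc(Nc2ccc(C#N)cc2)n1`: 88 nM

Compound 2 holds the highest number of the three in this assay, so it is the least toxic of the set on this read-out; its nearest neighbour is compound 1, with a 3.3-fold higher number from compound 1 to compound 2 (0.52 log units; beyond the scatter) separating them, and compound 3 lies furthest off, with a 14-fold lower number from compound 2 to compound 3 (1.13 log units; beyond the scatter) between them. Both of those steps concern a methyl against hydrogen on an aromatic carbon of the shared core.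

Compound 4, `N#Cc1ccc(Nc2nccc(NC3CCCCC3)n2)cc1`, is not yet measured. It differs from compound 2 only in cyclohexyl in place of cyclopropyl on a nitrogen on an aromatic ring: cut one bond further out, the change reads cyclopropylamino to cyclohexylamino. For the measured compounds named here, no measured pair touches this nitrogen substituent; the two steps on record both sit on the aromatic carbon and give no reading, in either direction, on what an enlarged ring on the amine does to cytotoxicity here. The honest position is therefore no expected step beyond the scatter, with a wide band around it: compound 4 is estimated at 1000 nM (range 250 nM to 4000 nM), which means an expected step of a 1.2-fold lower number from compound 2 to compound 4 (0.08 log units; within the scatter), carrying little confidence either way.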

Compound 4, half-maximal cytotoxic concentration: 7330 nM
Estimate against measurement, compound 4: 7.3-fold (0.87 log units) below; the measured number lies above the stated range.
By their numbers in this assay, from the lowest: compound 3; then compound 1; then compound 2; then compound 4.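

In this assay, for the compounds shown here, the first reading on this nitrogen substituent comes from cyclohexyl in place of cyclopropyl on a nitrogen on an aromatic ring, which gives a 6.2-fold higher number from compound 2 to compound 4 (0.79 log units; beyond the scatter), in the direction of lower toxicity in this test. Going by these compounds alone, the read-out therefore responds to the ring on the amine as well as to the methyl against hydrogen on an aromatic carbon of the shared core, the only kind of change the earlier pairs covered. Nothing measured here bears on why the number rises with this change.

On these data alone, this single pair gives two ring sizes and no more, so it remains open whether cyclopentyl would fall on the same line, and whether an open chain such as isopropyl or a ring carrying oxygen such as tetrahydropyranyl would move the number the same way. As far as these compounds go, the cyclohexylamino group is also read only on the core of compound 2, so whether the step carries over to the methyl-bearing cores of compound 1 and compound 3 remains unknown.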